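The compounds below may be only part of what the source reports. "The series", "measured", "known", "first", "only" and "open" are said of these compounds alone.

Of the compounds shown here, two have been measured so far in an ADME assay on NCI-H460 cells (Homo sapiens) for cytotoxicity (a higher number here means a weaker inhibitor, a lower number a stronger inhibitor), as follows.

- Compound 1 `Oc1cc2cc(c1)Oc1c(O)cc(cc1O)CCCCCCC/C=C/CCCCC2` gives 28000 nM in this test
- Compound 2 `Oc1cc2cc(c1)Oc1c(O)cc(cc1O)[C@H](O)CCCCCCCCCCCCC2` gives 27000 nM in this test

Compound 2 has the lower of the two numbers only nominally, since compound 2 (27000 nM) lies within the scatter of compound 1 (28000 nM). Compound 3 `Oc1cc2cc(c1)Oc1c(O)cc(cc1O)CCCCCCCCCCCCCC2` follows from compound 2 through one change, (hydrogen in place of hydroxy on a saturated ring carbon), which is hydrogen in place of hydroxy on a saturated ring carbon. For the measured compounds named here, no measured pair isolates this change, so the data give no direct size for it. With only these two close values to go on, no step beyond the scatter is expected in this assay and no direction is favoured. The estimated 1.0-fold lower number from compound 2 to compound 3 (0.02 log units; within the scatter) is therefore small. For compound 3 the expected value is 26000 nM with an estimated range from 13000 nM to 50000 nM in this test.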

Compound 3, half-maximal inhibitory concentration: 24000 nM
Estimate against measurement, compound 3: 1.1-fold (0.03 log units) above; the measured number falls inside the stated range.
By their numbers in this assay, from the lowest: compounds 3, 2 and 1 (each within the scatter of the next).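

In this assay, replacing the hydroxy group on this saturated ring carbon with hydrogen gives a 1.1-fold lower number from compound 2 to compound 3 (0.05 log units; within the scatter). For the compounds shown here, this is the first measured pair that isolates a single structural difference, and it shows that the read-out does not distinguish hydroxy from hydrogen at this position. Nothing on hand offers an explanation for this result.

Going by these compounds, it remains open whether an amine, a carboxylic acid or a methyl group on this same ring carbon would give a number beyond the scatter. The compounds shown also leave open how the opposite configuration at the hydroxy-bearing carbon would read, and whether replacing a hydroxy group elsewhere on the shared core with a methoxy group would move the number at all.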